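From Chloro to Bromo: Estimating Compound 4

This account rests on a few compounds, and the source may have more. Where it says the series, first, only, none or still open, it means among the compounds named here.

Compound 1, `Fc1ccc(C2=NN(c3nc(-c4ccc(Br)cc4)cs3)C(c3ccc4c(c3)OCCO4)C2)cc1`, gives 4110 nM in a functional assay on B16-F10 cells (Mus musculus) for antiproliferative activity, read by MTT assay, with a stated time of 48 h; a lower number here means a stronger inhibitor, a higher number a weaker inhibitor.
Compound 2, `Cc1ccc(C2=NN(c3nc(-c4ccc(Br)cc4)cs3)C(c3ccc4c(c3)OCCO4)C2)cc1`, gives 1680 nM in this assay.
Compound 3, `Clc1ccc(C2=NN(c3nc(-c4ccc(Br)cc4)cs3)C(c3ccc4c(c3)OCCO4)C2)cc1`, gives 2150 nM in this assay.

Within the data shown here, all three share one core and differ only in the single group on an aromatic carbon of one six-membered ring. Among the measured compounds shown here, on the numbers so far, compound 3 stands second highest of three; the step of a 1.3-fold higher number from compound 2 to compound 3 (0.11 log units; within the scatter) and the step of a 1.9-fold lower number from compound 1 to compound 3 (0.28 log units; within the scatter) both sit within the scatter, so compound 3 cannot be ordered against either neighbour. For the measured compounds named here, the only step beyond the scatter is a 2.4-fold lower number from compound 1 to compound 2 (0.39 log units; beyond the scatter).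

Compound 4, `Brc1ccc(C2=NN(c3nc(-c4ccc(Br)cc4)cs3)C(c3ccc4c(c3)OCCO4)C2)cc1`, is not yet measured. It differs from compound 3 by bromo in place of chloro on an aromatic carbon. The measured step that bears on this is the earlier halogen swap, a 1.9-fold lower number from compound 1 to compound 3 (0.28 log units; within the scatter), which stayed within the scatter. A step of similar small size, if any, is therefore expected in this assay, most likely toward a slightly lower number but not beyond the scatter. Compound 4 is expected to give about 1800 nM, with a range from 800 nM to 4000 nM. This estimate means an expected step of a 1.2-fold lower number from compound 3 to compound 4 (0.08 log units; within the scatter).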

Compound 4, half-maximal inhibitory concentration: 430 nM
Compound 4: the middle estimate sits 4.2-fold (0.62 log units) above what was measured; the measured number lies below the stated range.
By their numbers in this assay, from the lowest: compound 4; then compounds 2, 3 and 1 (each within the scatter of the next, the first and the last beyond it).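

Until now, changing the group at this position had shifted this assay only slightly, but the change from 4-chlorophenyl to 4-bromophenyl gives a 5.0-fold lower number from compound 3 to compound 4 (0.70 log units; beyond the scatter). Bromo also stands apart from the other two groups, with a 3.9-fold lower number from compound 2 to compound 4 (0.59 log units; beyond the scatter) and a 9.6-fold lower number from compound 1 to compound 4 (0.98 log units; beyond the scatter), which makes compound 4 the strongest inhibitor of the four. Swapping one halogen for another here therefore has no uniform effect: a 1.9-fold lower number from compound 1 to compound 3 (0.28 log units; within the scatter) was a small step, so that step gave little guide to the size of the next one.

Nothing available explains why bromo stands out. On these data alone, it also remains open whether iodo, the next halogen, would lower the number further, or whether a methoxy group or an amine at this position would come close to bromo.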